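The source may report more compounds than this note shows. Statements on the series, on what has been measured and on what is new or still open speak of the compounds shown alone.

Measured in a functional assay on thoracic aorta (Rattus norvegicus, strain Wistar), with a stated time of 15 min; a lower number here means that less compound is needed, a higher number that more compound is needed for the effect:

- Compound 1 `CCOc1ccc(Br)cc1C(C)NC(=O)N(C)S(=O)(=O)c1ccc(C)cc1`: 28600 nM
- Compound 2 `CCOc1ccc(Br)cc1C(C)NC(=O)NS(=O)(=O)c1ccccc1`: > 300000 nM (a limit of the assay, not a number)

Compound 2 sits at the limit of > 300000 nM in this assay, at which 1 of the 2 values shown sits. Its true value is therefore unknown, and in this assay it gave no half-maximal effective concentration that could be reported as a number.

Compound 3 `CCOc1ccc(Br)cc1C(C)NC(=O)N(C)S(=O)(=O)c1ccccc1` is built from compound 2 by a single change: methyl in place of hydrogen on an amide-type nitrogen. Compound 1 also has a methyl on that nitrogen, and compound 1 reaches a real number at 28600 nM. Among the measured compounds shown here, that one compound is the only guide here, so the expectation is loose. A clear step towards a lower number is expected, well beyond the usual scatter, with less compound needed for the effect. As far as these compounds go, the expected step is an at least 7.5-fold lower number from compound 2 to compound 3 (0.87 log units; beyond the scatter), and its true size stays open while compound 2 has only a limit. The estimated value for compound 3 is 40000 nM, with an expected range of 12000 nM to 150000 nM.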

Compound 3, half-maximal effective concentration: 19800 nM
Compound 3: the middle estimate sits 2.0-fold (0.31 log units) above what was measured, within the range that was stated.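

In this assay, a single methyl in place of hydrogen on the amide-type nitrogen gives an at least 15-fold lower number from compound 2 to compound 3 (1.18 log units; beyond the scatter), the first direct view of this change in a pair that differs in one place only. As far as these compounds go, compound 2 stands at a limit of the assay rather than a number, so the true size of this step stays open and only its minimum is known: the limit of > 300000 nM in this assay, at which 1 of the 3 values shown sits. Hydrogen in place of methyl on an aromatic carbon gives a 1.4-fold lower number from compound 1 to compound 3 (0.16 log units; within the scatter), which lies within the scatter, so among these compounds the methyl on the nitrogen is the change that shows a clear effect, while the methyl on the aromatic carbon does not.

The compounds shown leave open whether an ethyl group or a longer chain on that nitrogen would lower the number further or raise it again, and whether an acetyl group there would serve as the methyl does. They also leave open why the methyl has this effect, and whether a chlorine or a methoxy group on that aromatic carbon would move the number beyond the scatter.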